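Moving an ester around the ring: compound 1 to compound 4

A few compounds are considered here, and "the series" means these few. Any claim that something is new, unique, unknown or untested is made for them only; others in the source may bear on it.

The three measured compounds, read in an assay on isolated protein for binding affinity to L-selectin (Homo sapiens), read by ELISA, tested at 500 uM; a higher number here means more inhibition at the concentration tested (going by the name of the read-out), a lower number less inhibition:
compound 1, `CCCCCCCCCCOc1cccc(OCCCCCC(=O)N(Cc2ccc(C(=O)OC)cc2)c2ccc(C(=O)OC)cc2)c1`: 75%
compound 2, `CCCCCCCCCCOc1cc(OCCCCCCCCCC)cc(OCCCCCC(=O)N(c2ccc(C(=O)OC)cc2)c2ccc(C(=O)OC)c(C(=O)OC)c2)c1`: 95%
compound 3, `CCCCCCCCCCOc1cc(OCCCCCCCCCC)cc(OCCCCCC(=O)N(Cc2ccc(C(=O)O)cc2)c2cccc(C(=O)O)c2)c1`: 92%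

Compound 1 gives the lowest of the three numbers. Compound 3 is the nearest to it, yet its number is higher by a gap beyond the usual scatter, and compound 2 is the furthest, higher again by a gap beyond the scatter. Neither of those two compounds differs from compound 1 in a single place, so no isolated step can be read from them; the pair with compound 3 changes the ester groups and the outer chain at once, and the pair with compound 2 does so too.

Compound 4, `CCCCCCCCCCOc1cccc(OCCCCCC(=O)N(Cc2ccc(C(=O)OC)cc2)c2cccc(C(=O)OC)c2)c1`, differs from compound 1 in one place: 3-(methoxycarbonyl)phenyl in place of 4-(methoxycarbonyl)phenyl on an amide-type nitrogen. Within the data shown here, no measured pair shows a change of this kind on its own, so there is nothing to scale an expectation by. The same atoms are kept and only joined differently, and such a rearrangement is expected to give a step that stays within the scatter, in no clear direction. The expected step, no change at the digits printed from compound 1 to compound 4 (within the scatter), is therefore small. Compound 4 is estimated to give about 75% in this assay, with a range from 60% to 88%.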

Compound 4, a percentage reported as inhibition, at one concentration (the size of the read-out at that concentration, not a potency): 86%
Compound 4: middle estimate off by 11 percentage points, on the low side; the range from low to high includes it.
By their numbers in this assay, from the lowest: compound 1; then compounds 4, 3 and 2 (each within the scatter of the next).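

In this assay, swapping 4-(methoxycarbonyl)phenyl for 3-(methoxycarbonyl)phenyl on the amide-type nitrogen gives a number 11 percentage points higher from compound 1 to compound 4 (beyond the scatter) and so counts as a modest step. Among these compounds, compounds 2 and 3 each differ from compound 1 in more than one place, so this pair is the first to isolate this position: the group keeps the same atoms and the same counts of donors and acceptors, and moving the ester alone still shifts the number by more than the usual scatter. Nothing available explains why this rearrangement changes the number.

On these data alone, what other groups this position accepts remains open, for example a nitrile or a primary amide in place of the methoxycarbonyl group on this ring. Among the compounds shown here, with only one pair to read, it is also open whether the same move would give a similar step in a compound that carries a different outer part, or whether the other methoxycarbonyl group in compound 4 responds to such a move in the same way.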